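This account rests on a few compounds, and the source may have more. Where it says the series, first, only, none or still open, it means among the compounds named here.

Compound 1 `O=C1N=C(N2CCC[C@H]2C(=O)Nc2ccc3ncnc(Nc4cccc(Cl)c4)c3c2)S/C1=C/c1ccc(Br)s1` is the reference point of this account. In a functional assay on HepG2 cells (Homo sapiens) for antiproliferative activity, read by MTT assay (a lower number here means a stronger inhibitor, a higher number a weaker inhibitor), compound 1 gives > 50000 nM, which is a limit of the assay rather than a number, and it stands at the limit of > 50000 nM in this assay, at which 1 of the 3 values shown sits. Two measured neighbours vary the same group at the same place. Compound 2 `O=C1N=C(N2CCC[C@H]2C(=O)Nc2ccc3ncnc(Nc4cccc(Cl)c4)c3c2)S/C1=C/c1cccc(Br)n1` gives 2700 nM in this assay, and compound 3 `O=C1N=C(N2CCC[C@H]2C(=O)Nc2ccc3ncnc(Nc4cccc(Cl)c4)c3c2)S/C1=C/c1cccc(Cl)c1` gives 27600 nM. The step of an at least 18-fold lower number from compound 1 to compound 2 (1.26 log units; beyond the scatter) is large, whereas an at least 1.8-fold lower number from compound 1 to compound 3 (0.25 log units; that floor lies within the scatter) has a floor that lies within the scatter; between the two neighbours, a 10-fold higher number from compound 2 to compound 3 (1.01 log units; beyond the scatter).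

Compound 4 `Cc1cccc(/C=C2/SC(N3CCC[C@H]3C(=O)Nc3ccc4ncnc(Nc5cccc(Cl)c5)c4c3)=NC2=O)n1` has not been measured. It differs from compound 1 by 6-methylpyridin-2-yl in place of 5-bromothiophen-2-yl on a double-bonded chain carbon bound to a double-bonded ring carbon. Of the measured steps, an at least 18-fold lower number from compound 1 to compound 2 (1.26 log units; beyond the scatter) bears most directly on this change: compound 2 carries 6-bromopyridin-2-yl at the same place, so the two differ only in methyl standing where bromine stood. The step to compound 3, an at least 1.8-fold lower number from compound 1 to compound 3 (0.25 log units; that floor lies within the scatter), is less relevant, as 3-chlorophenyl has no ring nitrogen. A large downward step is therefore expected, an at least 12-fold lower number from compound 1 to compound 4 (1.09 log units; beyond the scatter), of roughly the size seen in an at least 18-fold lower number from compound 1 to compound 2 (1.26 log units; beyond the scatter), with some allowance for the exchange of bromine for methyl. Compound 4 is expected to give about 4000 nM in this assay, with a likely range from 1500 nM to 15000 nM.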

Compound 4, half-maximal inhibitory concentration: 4500 nM
For compound 4 the middle estimate is 1.1-fold (0.05 log units) below the measured one, within the range that was stated.
By their numbers in this assay, from the lowest: compounds 2 and 4 (each within the scatter of the next); then compound 3. At a limit, above all of these: compound 1.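

Methyl serves as well as bromine here: the step of a 1.7-fold higher number from compound 2 to compound 4 (0.22 log units; within the scatter) shows that in this assay the gain seen with 6-bromopyridin-2-yl at this place does not depend on the bromine, and the two pyridine compounds cannot be ranked against each other. The replacement of 5-bromothiophen-2-yl by 6-methylpyridin-2-yl remains a large change, an at least 11-fold lower number from compound 1 to compound 4 (1.04 log units; beyond the scatter), and the step of a 6.1-fold lower number from compound 3 to compound 4 (0.79 log units; beyond the scatter) lies beyond the scatter, so among these four compounds both with a pyridin-2-yl ring give lower numbers than compound 3, and none goes against this. Compound 1 remains a limit of the assay rather than a number, so the steps from it give only floors: the limit of > 50000 nM in this assay, at which 1 of the 4 values shown sits.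

The compounds shown leave open whether the gap to compound 3 follows the ring nitrogen or the exchange of chlorine for methyl or bromine, which a 3-methylphenyl group at this place would help to separate. They also leave open how far the substituent on the pyridine can vary, for instance with an amine, a methoxy group or a plain hydrogen in place of methyl.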